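This account rests on a few compounds, and the source may have more. Where it says the series, first, only, none or still open, it means among the compounds named here.

Compound 1 `COc1ccc(-c2nc(CC(=O)c3cccc(Cl)c3)nc3ccsc23)cn1`: 30000 nM
Compound 2 `COc1ccc(-c2nc(CS(=O)(=O)c3cccc(Cl)c3)nc3ccsc23)cc1`: 69000 nM

Within the data shown here, in an ADME assay on cells (Homo sapiens) for cytotoxicity, read by resazurin assay, with a stated time of 5 days (on this read-out lower numbers stand for higher toxicity in this test and higher numbers for lower toxicity in this test), compound 1 gives 30000 nM, the lower of the two numbers so far, and compound 2 gives 69000 nM, a gap beyond the usual scatter. Compound 3 `COc1ccc(-c2nc(CSc3cccc(Cl)c3)nc3ccsc23)cn1` has not yet been measured in this assay. It differs from compound 1 in one place: (3-chlorophenyl)sulfanyl in place of (3-chlorophenyl)carbonyl on a saturated chain carbon bound to an aromatic carbon. In words, (3-chlorophenyl)sulfanyl stands in place of (3-chlorophenyl)carbonyl on a saturated chain carbon bound to an aromatic carbon. Among the measured compounds shown here, no measured pair of compounds shows this change on its own, so the expectation is a cautious one. The expected change, a 1.2-fold lower number from compound 1 to compound 3 (0.08 log units; within the scatter), is estimated to stay within the scatter, leaning slightly towards a lower number. For compound 3 the estimate is 25000 nM, with an expected range of 10000 nM to 60000 nM.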

Compound 3, half-maximal cytotoxic concentration: > 10000 nM
Compound 3 was reported as a limit (the forecaster's own chance of this, stated with the estimate: 15%); the middle value is on the limit's open side.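

In this assay compound 3 gives > 10000 nM, which is a limit of the assay and not a number. Among these compounds, no step from compound 1 to compound 3 can be read from it. The compounds shown leave open whether (3-chlorophenyl)sulfanyl in place of (3-chlorophenyl)carbonyl shifts this read-out at all, and in which direction.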